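Removing the 4-Methylpiperazin-1-yl Group: Compound 1 to Compound 4

The source may hold more compounds than are shown below. What is called first, only, known or untested is meant among the compounds shown, and "the series" means these compounds.

All numbers here come from an ADME assay on BHK cells (Mesocricetus auratus) for cytotoxicity, read by MTT assay, with a stated time of 96 h; on this read-out higher numbers stand for lower toxicity in this test and lower numbers for higher toxicity in this test. Compound 1 `CN1CCN(CC(=O)Nc2ccc(-c3nc4cc(C(F)(F)F)ccc4n3C)cc2)CC1` gives 16000 nM in this assay. Compound 3 `O=[N+]([O-])c1ccc(-c2nc3cc(C(F)(F)F)ccc3[nH]2)c([N+](=O)[O-])c1` gives 8000 nM in this assay, and the two numbers lie within the usual scatter of each other, so neither compound can be called the less toxic of the pair. Compound 2 `COc1ccc(-c2nc3cc([N+](=O)[O-])ccc3[nH]2)c(OC)c1OC` reaches only the limit of the test, > 100000 nM, so no number is known for it; the limit of > 100000 nM in this assay, at which 1 of the 3 values shown sits, covers this value. Of the two actual numbers shown, compound 1 holds the higher one.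

Compound 4 `CCC(=O)Nc1ccc(-c2nc3cc(C(F)(F)F)ccc3n2C)cc1` has not yet been measured. It differs from compound 1 in a single place: methyl in place of 4-methylpiperazin-1-yl on a saturated chain carbon bound to a carbonyl carbon. Among the compounds with values here, no pair of measured compounds shows this same kind of change, so there is no measured step to lean on, and the three measured compounds are too different from one another to give a direction. In this assay the expected step, a 1.3-fold lower number from compound 1 to compound 4 (0.12 log units; within the scatter), is a change that stays within the scatter. Compound 4 is therefore estimated to give 12000 nM in this assay, with an expected range from 3000 nM to 50000 nM.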

Compound 4, half-maximal cytotoxic concentration: > 100000 nM
Compound 4 ended at the assay's limit (the forecaster's own chance of this, stated with the estimate: 10%); at least 8.3-fold (0.92 log units) between middle value and limit.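

Swapping 4-methylpiperazin-1-yl for methyl on a saturated chain carbon bound to a carbonyl carbon gives, in this assay, an at least 6.2-fold higher number from compound 1 to compound 4 (0.79 log units; beyond the scatter). Within the data shown here, this is the first comparison here between compounds that differ in one place, so it shows what the earlier compounds could not: with the rest of the structure held fixed, the group at this position matters, and the version with methyl is the less toxic in this test. Compound 4 stands at a limit of the test and has no actual number, so only the smallest possible size of the step is known: the limit of > 100000 nM in this assay, at which 2 of the 4 values shown sit.

The compounds shown leave open which part of the 4-methylpiperazin-1-yl group goes with the toxicity seen for compound 1, and whether a simple amine such as dimethylamino at the same place would side with compound 1 or with compound 4. They also leave open how a carboxylic acid or a longer chain without any amine would behave there, and whether the same change would give a similar step on a different core.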